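A few compounds are considered here, and "the series" means these few. Any claim that something is new, unique, unknown or untested is made for them only; others in the source may bear on it.

Measured so far:
- compound 1, `CN(C(=O)NC(=O)c1ccc(F)c(F)c1)c1nc(C(F)(F)F)c(C(=O)N/N=C/c2ccc(C(F)(F)F)cc2)s1`: in a functional assay on HepG2 cells (Homo sapiens) for inhibition, read by MTT assay, with a stated time of 72 h (on this read-out higher numbers stand for weaker inhibition and lower numbers for stronger inhibition), compound 1 gives 6.26 ug/mL.
- compound 2, `Cc1nc(N(C)C(=O)NC(=O)c2c(F)cccc2F)sc1C(=O)N/N=C/c1ccccc1Cl`: in this assay compound 2 reaches only a limit, > 100 ug/mL.
- compound 3, `CNc1nc(C(F)(F)F)c(C(=O)N/N=C/c2ccc(C(F)(F)F)cc2)s1`: in this assay compound 3 also reaches only a limit, > 100 ug/mL.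

Compound 2 therefore stands at the limit of this assay, not at a number, and it shares that place with compound 3; the limit of > 100 ug/mL in this assay, at which 2 of the 3 values shown sit, is where two of the three values sit. Only compound 1 gives a measured number. No two of these compounds differ in a single place, so no measured step is at hand.

Compound 4, `COc1cc(/C=N/NC(=O)c2sc(N(C)C(=O)NC(=O)c3c(F)cccc3F)nc2C)cc(OC)c1OC`, differs from compound 2 in one place: 3,4,5-trimethoxyphenyl in place of 2-chlorophenyl on a carbon with a double bond to nitrogen. Within the data shown here, with no measured step to lean on, the direction of the step from compound 2 to compound 4 is open. Because compound 2 gives only the limit > 100 ug/mL, the step of an at least 2.0-fold lower number from compound 2 to compound 4 (0.30 log units; that floor lies within the scatter) is expected to be either nothing beyond the scatter or a move toward stronger inhibition; a move toward weaker inhibition could not be seen. For compound 4 the expected value in this assay is 50 ug/mL, within a range of 10 ug/mL to 150 ug/mL, with a real chance that only a limit is reported again.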

Compound 4, half-maximal inhibitory concentration: > 100 ug/mL
Compound 4 gave a limit, no number (the forecaster's own chance of this, stated with the estimate: 50%); at least 2.0-fold (0.30 log units) between middle value and limit.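

Compound 2 and compound 4 each reach only a limit, so no step between them can be read: the limit of > 100 ug/mL in this assay, at which 3 of the 4 values shown sit.

On these data alone, whether 3,4,5-trimethoxyphenyl in place of 2-chlorophenyl changes inhibition at all, in either direction, stays open.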